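Swapping the Amide Substituent: From Compound 3 to Compound 4

The source may hold more compounds than are shown below. What is called first, only, known or untested is meant among the compounds shown, and "the series" means these compounds.

Compound 1 `CS(=O)(=O)c1ccc(C(=O)NCC(=O)N(Cc2ccccc2)Cc2ccccc2)cc1[N+](=O)[O-]`, compound 2 `CN(Cc1ccccc1F)C(=O)CNC(=O)c1ccc(S(C)(=O)=O)c([N+](=O)[O-])c1` and compound 3 `CC(C)N(C(=O)CNC(=O)c1ccc(S(C)(=O)=O)c([N+](=O)[O-])c1)C(C)C` share one core and differ only in the amine attached to its terminal carbonyl. In an assay on isolated protein for inhibition of vitamin D3 receptor (Homo sapiens), read by fluorescence polarization (a higher number here means a weaker inhibitor, a lower number a stronger inhibitor), compound 1 gives > 60000 nM, which is a limit of the assay and not a number. Compound 2 likewise gives > 60000 nM, again a limit. Compound 3 gives > 60000 nM, also a limit, so compound 3 stands exactly where every value shown stands: the limit of > 60000 nM in this assay, at which 3 of the 3 values shown sit. Compound 4 `CN(Cc1ccccc1)C(=O)CNC(=O)c1ccc(S(C)(=O)=O)c([N+](=O)[O-])c1` is the untested member, carrying (benzyl(methyl)amino in place of diisopropylamino on a carbonyl carbon). For the measured compounds named here, no step between measured compounds exists to guide the guess, so the step that the limit leaves unreadable from compound 3 to compound 4 is expected to be none beyond the scatter, because the limit of > 60000 nM in this assay, at which 3 of the 3 values shown sit, holds all three values shown. Compound 4 is therefore estimated at 100000 nM, within 30000 nM to 500000 nM.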

Compound 4, half-maximal inhibitory concentration: > 60000 nM
Compound 4: a limit, no number; the forecaster's own chance of this, stated with the estimate: 90%; the middle value is on the limit's open side.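

In this assay, for the compounds shown here, compound 4 gives > 60000 nM, a limit and not a number, so no step from compound 1, compound 2 or compound 3 to compound 4 can be read. The compounds shown leave open whether any amine on the shared core gives a readable value.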